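This account rests on a few compounds, and the source may have more. Where it says the series, first, only, none or still open, it means among the compounds named here.

Compound 1 `COc1ccc(C(=O)NC(N)=O)cc1NC(=O)C(C)Br`: > 20000 nM, a limit
Compound 2 `Cc1ccc(C(=O)NC(N)=O)cc1NC(=O)C(C)Cl`: > 20000 nM, a limit

Both compounds were tested in a functional assay on CCRF-CEM cells (Homo sapiens) for antiproliferative activity, read by trypan blue exclusion, with a stated time of 72 h; on this read-out lower numbers stand for stronger inhibition and higher numbers for weaker inhibition. Compound 2 gives only a limit on this read-out and no number, and compound 1 shares it: the limit of > 20000 nM in this assay, at which 2 of the 2 values shown sit.

The next compound is compound 3 `COc1ccc(C(=O)NC(N)=O)cc1NC(=O)C(C)Cl`, which differs from compound 2 in one place: methoxy in place of methyl on an aromatic carbon. Methoxy stands in place of methyl on an aromatic carbon, ortho to a ((1-chloroethyl)carbonyl)amino group and para to a carbamoylcarbamoyl group.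

Among the compounds with values here, no step between measured compounds is available in this assay, so the data give no direct size for this change. Compound 1, which carries methoxy at that place, gives > 20000 nM, again a limit, so no shift beyond the usual scatter is expected. The estimated step is a step that the limit leaves unreadable from compound 2 to compound 3. Compound 3 is expected at 25000 nM, with an estimated range of 12000 nM to 50000 nM, and the assay will probably report only a limit.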

Compound 3, half-maximal inhibitory concentration: > 20000 nM
Compound 3 gave a limit, no number; the forecaster's own chance of this, stated with the estimate: 85%; the middle value does not contradict the limit.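

Neither the step from compound 2 to compound 3 nor the step from compound 1 to compound 3 can be read, since all three compounds give only a limit: the limit of > 20000 nM in this assay, at which 3 of the 3 values shown sit.

The compounds shown leave open whether swapping methoxy for methyl or chloro for bromo changes the result in this assay, and what true value lies behind each limit.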